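Extending the Ether on the Urea Aryl Group

The source may report more compounds than this note shows. Statements on the series, on what has been measured and on what is new or still open speak of the compounds shown alone.

Of the compounds shown here, three have been measured so far, all sharing a core in which a basic amine chain and a chlorophenyl group sit on the same carbon. Compound 1 `Cc1cccc(Cl)c1C(=O)NC(CCN(C)C)c1ccc(Cl)cc1` carries an amide and in an assay on NIH3T3 cells with Urotensin-2 receptor (Homo sapiens) as the target (a higher number here means a larger maximal response, a lower number a smaller maximal response), compound 1 gives 105%. Compound 2 `Cc1ccccc1NC(=O)NC(CCN(C)C)c1ccc(Cl)cc1` replaces that amide with a urea and reaches 175%; the change gave a number 70 percentage points higher from compound 1 to compound 2 (beyond the scatter). Compound 3 `COc1ccc(NC(=O)NC(CCN(C)C)c2ccc(Cl)cc2)cc1` gives 195%, the highest of the three, with a number 20 percentage points higher from compound 2 to compound 3 (beyond the scatter).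

Compound 4 `CN(C)CCC(NC(=O)Nc1ccc(Oc2ccccc2)cc1)c1ccc(Cl)cc1` differs from compound 3 in one place: phenyl in place of methyl on an oxygen on an aromatic ring. Going by the values given here, no measured step exchanges methyl for phenyl on an oxygen, so none bears directly on this change. The nearest comparison is a number 20 percentage points higher from compound 2 to compound 3 (beyond the scatter), which also altered the group on that aromatic ring and was modest in size; the step of a number 70 percentage points higher from compound 1 to compound 2 (beyond the scatter) was large but concerned the carbonyl side. The expected step of a number 5 percentage points higher from compound 3 to compound 4 (within the scatter) in this assay is therefore small or none beyond the scatter. Compound 4 is estimated at 200%, with a range from 160% to 240%.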

Compound 4, largest response reached (reported as efficacy), in percent of the reference or control that the assay uses: 108%
Compound 4: the middle estimate sits 92 percentage points above what was measured; measured number below the stated range.
By their numbers in this assay, from the lowest: compounds 1 and 4 (each within the scatter of the next); then compound 2; then compound 3.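

In this assay, phenyl in place of methyl on an oxygen on an aromatic ring gives a number 87 percentage points lower from compound 3 to compound 4 (beyond the scatter), so this position does not accept the two groups alike. Both earlier steps raised the number, which makes this the first step shown to lower it, and the change that does so leaves the urea and the rest of the molecule untouched. No measurement available here explains the drop.

Still open, on these data alone, is whether ethoxy, a slightly longer chain on the same oxygen, would hold the response of compound 3 or already reduce it. Benzyloxy, which also carries a phenyl ring on that oxygen but through an added carbon, would help show whether the loss follows the ring itself or only this particular attachment.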